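The source may hold more compounds than are shown below. What is called first, only, known or untested is meant among the compounds shown, and "the series" means these compounds.

Among the measured compounds shown here, in a functional assay (Cavia porcellus) with sulfonylurea receptors; K-ATP channels (Homo sapiens) as the target (on this read-out higher numbers stand for weaker inhibition and lower numbers for stronger inhibition), compound 2 `CC(O)(C(=O)Nc1ccc(S(=O)(=O)c2ccc(C#N)cc2)cc1)C(F)(F)F` gives only a limit, > 30000 nM, and no number; it is the one member of the set sitting at the limit of > 30000 nM in this assay, at which 1 of the 3 values shown sits. Compound 4 `Cc1ccc(S(=O)(=O)c2ccc(NC(=O)C(C)(O)C(F)(F)F)cc2)cc1` differs from compound 2 by methyl in place of cyano on an aromatic carbon. Among the measured compounds only compound 1 `CC(O)(C(=O)Nc1ccc(S(=O)(=O)c2ccccc2)c(C#N)c1)C(F)(F)F` and compound 3 `CC(O)(C(=O)Nc1ccc(S(=O)(=O)c2ccccc2)c(Cl)c1)C(F)(F)F` differ from each other in one place: in this assay compound 1 gives 3800 nM and compound 3 gives 2200 nM, so a 1.7-fold lower number from compound 1 to compound 3 (0.24 log units; within the scatter). That exchange also removes a cyano group, but at another place and for chloro rather than methyl, so it bears on the present step only loosely. For the measured compounds named here, compound 2 differs from compound 1 and from compound 3 in more than one place, so no single step between them is given; their numbers show only that compound 2 sits at the limit while both others return a number. The step of an at least 3.0-fold lower number from compound 2 to compound 4 (0.47 log units; beyond the scatter) is therefore expected to move toward a lower number, of uncertain size. Compound 4 is estimated at 10000 nM, with a range from 2000 nM to 60000 nM, and a fair chance that this assay again reports only a limit.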

Compound 4, half-maximal inhibitory concentration: > 30000 nM
Compound 4: a limit, no number (the forecaster's own chance of this, stated with the estimate: 40%); middle value at least 3.0-fold (0.47 log units) away from the limit.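

Among the compounds shown here, no step from compound 2 to compound 4 can be read in this assay as both compounds return only a limit and no number: the limit of > 30000 nM in this assay, at which 2 of the 4 values shown sit. From the compounds shown here alone, whether 4-cyanophenyl and 4-methylphenyl differ at all on this read-out stays open.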